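Phenoxy to propyl with the amino group in place

This account rests on a few compounds, and the source may have more. Where it says the series, first, only, none or still open, it means among the compounds named here.

Measured in a functional assay on L1210 cells (Mus musculus), with a stated time of 48 h; a lower number here means a stronger inhibitor, a higher number a weaker inhibitor:
compound 1 `CCOC(=O)Nc1cc(NC(C)C(O)COc2ccccc2)c([N+](=O)[O-])c(N)n1`: 55000 nM
compound 2 `CCCCC(O)C(C)Nc1cc(NC(=O)OCC)nc(N)c1[N+](=O)[O-]`: 55000 nM
compound 3 `CCOC(=O)Nc1cc(NC(C)C(O)COc2ccccc2)c(N)c(N)n1`: 21000 nM

Compound 3, at 21000 nM, has the lowest number of the three, and the other two stand above it beyond the scatter. Compound 4 `CCCCC(O)C(C)Nc1cc(NC(=O)OCC)nc(N)c1N` differs from it by one exchange: propyl in place of phenoxy on a saturated chain carbon, two bonds along the chain from an oxygen on a saturated carbon. The same exchange, made with nitro in place of amino, gave no change at the digits printed from compound 1 to compound 2 (within the scatter). The amino for nitro exchange gave a modest 2.6-fold lower number from compound 1 to compound 3 (0.42 log units; beyond the scatter), and both compound 3 and compound 4 already carry that amino group. No step beyond the scatter is therefore expected in this assay. The estimated step is no change at the digits printed from compound 3 to compound 4 (within the scatter). Compound 4 is expected at 21000 nM, with an estimated range of 10000 nM to 45000 nM.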

Compound 4, half-maximal inhibitory concentration: 18000 nM
Compound 4: the middle estimate sits 1.2-fold (0.07 log units) above what was measured; low and high end bracket the measured number.
By their numbers in this assay, from the lowest: compounds 4 and 3 (each within the scatter of the next); then compounds 1 and 2 (each within the scatter of the next).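

In this assay, the exchange of phenoxy for propyl, repeated with the amino group in place, gives a 1.2-fold lower number from compound 3 to compound 4 (0.07 log units; within the scatter), so this position tolerates the change with either nitro or amino present: the same change on two cores in this assay, no change at the digits printed (within the scatter) from compound 1 to compound 2 and a 1.2-fold lower number (0.07 log units; within the scatter) from compound 3 to compound 4, 1.2-fold (0.07 log units) apart, within the scatter of two such steps. The amino for nitro exchange, now also seen with propyl on the chain, gives a 3.1-fold lower number from compound 2 to compound 4 (0.49 log units; beyond the scatter), and it matches its earlier step: the same change on two cores in this assay, a 2.6-fold lower number (0.42 log units; beyond the scatter) from compound 1 to compound 3 and a 3.1-fold lower number (0.49 log units; beyond the scatter) from compound 2 to compound 4, 1.2-fold (0.07 log units) apart, within the scatter of two such steps. Across these four compounds, the two exchanges behave independently of each other. Going by these compounds, whether a longer chain, an amine or a carboxylic acid in place of propyl would move the number in this assay stays open.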